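The source may report more compounds than this note shows. Statements on the series, on what has been measured and on what is new or still open speak of the compounds shown alone.

Measured in a functional assay on PC-3 cells (Homo sapiens) for antiproliferative activity, read by MTT assay, with a stated time of 48 h; on this read-out lower numbers stand for stronger inhibition and higher numbers for weaker inhibition:
- compound 1 `O=C(/C=C\Nc1ccc(F)cc1)c1cn(-c2ccccc2)nc1-c1ccc(Cl)cc1`: > 50000 nM, a limit of this assay rather than a number
- compound 2 `O=C(/C=C\Nc1ccc(Cl)cc1)c1cn(-c2ccccc2)nc1-c1ccc(Cl)cc1`: 3890 nM
- compound 3 `COc1cc(-c2nn(-c3ccccc3)cc2C(=O)/C=C\Nc2ccc(F)cc2)cc(OC)c1OC`: 7700 nM

Among the compounds with values here, the one change measured twice is chloro in place of fluoro on an aromatic carbon, giving an at least 12-fold lower number from compound 1 to compound 2 (1.10 log units; beyond the scatter). That step rests on a limit, (the limit of > 50000 nM in this assay, at which 1 of the 3 values shown sits), so its true size is not pinned down. Compound 3 and compound 2 lie within the scatter of each other; the difference between the two cores is not broken down here.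

Compound 4 `COc1cc(-c2nn(-c3ccccc3)cc2C(=O)/C=C\Nc2ccc(Cl)cc2)cc(OC)c1OC` is unmeasured and carries the same change, (chloro in place of fluoro on an aromatic carbon), on the core of compound 3. A gain in the same direction is expected in this assay, but likely smaller than the bounded step because an at least 12-fold lower number from compound 1 to compound 2 (1.10 log units; beyond the scatter) sits on the limit (the limit of > 50000 nM in this assay, at which 1 of the 3 values shown sits), so the step from compound 3 to compound 4 is estimated at a 3.9-fold lower number from compound 3 to compound 4 (0.59 log units; beyond the scatter). Compound 4 is expected at 2000 nM, between 600 nM and 6500 nM.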

Compound 4, half-maximal inhibitory concentration: 11200 nM
Compound 4: middle estimate off by 5.6-fold (0.75 log units), on the low side; measured number above the stated range.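

On the second core in this assay, chloro in place of fluoro gives a 1.5-fold higher number from compound 3 to compound 4 (0.16 log units; within the scatter), so the gain seen on the first core does not reappear here. The change therefore does not carry over as a fixed increment between these two cores: the same change on two cores in this assay, an at least 12-fold lower number (1.10 log units; beyond the scatter) from compound 1 to compound 2 and a 1.5-fold higher number (0.16 log units; within the scatter) from compound 3 to compound 4, at least 18-fold (1.27 log units) apart, beyond the scatter of two such steps. The earlier step rests on the limit of compound 1, so its true size stays unfixed, and the two cores alone do not show which part of them separates the steps: the limit of > 50000 nM in this assay, at which 1 of the 4 values shown sits.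

Left open is how bromo, methyl or trifluoromethyl in the same place would read on either core. Also open, as far as these compounds go, is how the change reads on a core carrying hydroxy or an amine in place of the methoxy groups.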